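Chloro for Methoxy on an Anilide Ester Series

The source may hold more compounds than are shown below. What is called first, only, known or untested is meant among the compounds shown, and "the series" means these compounds.

The study concerns a set of cinnamate esters carrying an anilide tail, all built on the shared core of compound 1 `CCOc1ccc(COc2c(OC)cc(/C=C/C(=O)OCC(=O)Nc3ccc(Cl)cc3)cc2OC)cc1`, compound 2 `COc1ccc(NC(=O)COC(=O)/C=C/c2cc(OC)c(OCc3ccc(Cl)c(Cl)c3)c(OC)c2)cc1` and compound 3 `COc1ccc(NC(=O)COC(=O)/C=C/c2cc(OC)c(OCc3ccccc3)c(OC)c2)cc1`. In a functional assay on ECa-109 cells (Homo sapiens) for cytotoxicity, read by MTT assay, with a stated time of 72 h (on this read-out lower numbers stand for stronger inhibition and higher numbers for weaker inhibition), compound 1 reaches only the limit of the assay, > 200000 nM. In this assay compound 2 likewise gives only a limit, > 200000 nM. Compound 3 also stops at a limit, > 200000 nM. For the measured compounds named here, the one step that can be drawn between measured compounds, a step that the two limits leave unreadable from compound 2 to compound 3, therefore has no readable size, because the limit of > 200000 nM in this assay, at which 3 of the 3 values shown sit, sets both of its ends.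

Compound 4 `COc1cc(/C=C/C(=O)OCC(=O)Nc2ccc(Cl)cc2)cc(OC)c1OCc1ccc(Cl)c(Cl)c1` differs from compound 2 by a single change on the anilide side: chloro in place of methoxy on an aromatic carbon. Going by the values given here, no measured step speaks to this change; the only step available, a step that the two limits leave unreadable from compound 2 to compound 3, touches a different part of the molecule and is itself unreadable. Where compound 2 stands is thus known only as a limit, and nothing among the three measured values points to a gain in this assay.

Compound 4 is accordingly expected to sit near 250000 nM, with a range from 100000 nM to 1000000 nM, and the expected step that the limit leaves unreadable from compound 2 to compound 4 is estimated to be none beyond the scatter.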

Compound 4, half-maximal inhibitory concentration: > 200000 nM
Compound 4 was reported as a limit (the forecaster's own chance of this, stated with the estimate: 85%); the middle value does not contradict the limit.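

In this assay compound 4 gives > 200000 nM, which is a limit. The steps to it from compound 2 and from compound 1 cannot be read, because both ends of each are set by the same limit: the limit of > 200000 nM in this assay, at which 4 of the 4 values shown sit.

The compounds shown leave open whether chloro in place of methoxy on an aromatic carbon changes the read-out in this assay at all.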